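Adding a bromo group to compound 1

The source may hold more compounds than are shown below. What is called first, only, known or untested is meant among the compounds shown, and "the series" means these compounds.

Going by the values given here, in a functional assay on NCI-H520 cells (Homo sapiens) (on this read-out lower numbers stand for stronger inhibition of growth and higher numbers for weaker inhibition of growth), compound 1 (`O=S(=O)(/C=C/c1ccc(Cl)c(Cl)c1)Cc1ccc(Nc2ncnc3ccccc23)cc1`) gives 32000 nM, the lower of the two numbers so far, while compound 2 (`O=S(=O)(/C=C/c1ccc(O)cc1)Cc1ccc(Nc2ncnc3ccccc23)cc1`) gives 100000 nM. Compound 3 (`O=S(=O)(/C=C/c1ccc(Cl)c(Cl)c1)Cc1ccc(Nc2ncnc3ccc(Br)cc23)cc1`) keeps the 3,4-dichlorophenyl of compound 1 and carries bromo in place of hydrogen on an aromatic carbon of a six-membered aromatic ring of carbon only, part of a fused or bridged system of two rings: bromo in place of hydrogen on an aromatic carbon. Among the compounds with values here, the only measured step, a 3.1-fold higher number from compound 1 to compound 2 (0.49 log units; beyond the scatter), is modest and exchanges 3,4-dichlorophenyl for 4-hydroxyphenyl elsewhere in the molecule. It offers a rough size for one change in this series, but no direction for the new bromo. No shift beyond the scatter is therefore expected in this assay. The expected change is a 1.3-fold lower number from compound 1 to compound 3 (0.11 log units; within the scatter). For compound 3 the estimate is 25000 nM, with an expected range of 8000 nM to 70000 nM.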

Compound 3, concentration for 50% growth inhibition: > 100000 nM
Compound 3 gave a limit, no number; the forecaster's own chance of this, stated with the estimate: 15%; middle value at least 4.0-fold (0.60 log units) away from the limit.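

In this assay compound 3 gives > 100000 nM as a limit and not a number. Bromo in place of hydrogen on an aromatic carbon gives an at least 3.1-fold higher number from compound 1 to compound 3 (0.49 log units; beyond the scatter) and so shows that growth inhibition answers to a change on the six-membered aromatic ring of carbon only, which the earlier step, confined to the replacement of 3,4-dichlorophenyl, could not show. The step has a lower bound only, and its full size cannot be read: the limit of > 100000 nM in this assay, at which 1 of the 3 values shown sits.

From the compounds shown here alone, whether fluoro, methoxy or an amine on this same aromatic carbon would keep growth inhibition near that of compound 1 remains open. Also open, going by these compounds, is whether the loss belongs to bromo alone or to any group other than hydrogen at this place.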